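A few compounds are considered here, and "the series" means these few. Any claim that something is new, unique, unknown or untested is made for them only; others in the source may bear on it.

Working notes on the triazole-linked series in a functional assay on RAW264.7 cells (Mus musculus) for inhibition, read by Griess assay, with stated times of 2 h and 24 h; on this read-out higher numbers stand for weaker inhibition and lower numbers for stronger inhibition. Within the data shown here, compound 3 `COc1ccc([C@@H]2CC(=O)c3c(O)cc(OCc4cn(Cc5ccccc5C#N)nn4)cc3O2)cc1O` gives 14600 nM and stands second highest of the three numbers measured so far. Compound 1 `COc1ccc([C@@H]2CC(=O)c3c(O)cc(OCc4cn(Cc5cccc(Cl)c5)nn4)cc3O2)cc1O` gives 18200 nM and compound 2 `COc1ccc([C@@H]2CC(=O)c3c(O)cc(OCc4cn(CC5CC5)nn4)cc3O2)cc1O` gives 11900 nM; the three values sit close together, as the steps show: a 1.5-fold lower number from compound 1 to compound 2 (0.18 log units; within the scatter), a 1.2-fold lower number from compound 1 to compound 3 (0.10 log units; within the scatter) and a 1.2-fold higher number from compound 2 to compound 3 (0.09 log units; within the scatter).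

Compound 4 `COc1ccc([C@@H]2CC(=O)c3c(O)cc(OCc4cn(Cc5ccc(Cl)cc5)nn4)cc3O2)cc1O` differs from compound 3 by 4-chlorophenyl in place of 2-cyanophenyl on a saturated chain carbon bound to an aromatic nitrogen. Among the measured compounds shown here, the steps that bear on this exchange are the one from compound 1 to compound 3, where a chlorophenyl group was replaced by the 2-cyanophenyl group on the same saturated chain carbon, and the one from compound 2 to compound 3; neither moved the read-out beyond the scatter, so no step of consequence is expected here either, in this assay. Compound 4 is therefore estimated at 16000 nM, with a range of 8000 nM to 32000 nM, the expected step from compound 3 to compound 4 being a 1.1-fold higher number from compound 3 to compound 4 (0.04 log units; within the scatter), which is essentially no change.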

Compound 4, half-maximal inhibitory concentration: 17800 nM
Compound 4: middle estimate off by 1.1-fold (0.05 log units), on the low side; low and high end bracket the measured number.
By their numbers in this assay, from the lowest: compounds 2, 3, 4 and 1 (each within the scatter of the next).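

In this assay, 4-chlorophenyl on a saturated chain carbon bound to an aromatic nitrogen stays within the scatter of all three earlier groups (a 1.2-fold higher number from compound 3 to compound 4 (0.09 log units; within the scatter); a 1.5-fold higher number from compound 2 to compound 4 (0.17 log units; within the scatter); a 1.0-fold lower number from compound 1 to compound 4 (0.01 log units; within the scatter)). Among these compounds, the step from 3-chlorophenyl is the first pair here in which both groups are chlorophenyl, and the two chlorophenyl isomers cannot be told apart in this read-out. No measured data on the compounds bear on why these values remain so close.

The four groups shown, cyclopropyl, 2-cyanophenyl, 3-chlorophenyl and 4-chlorophenyl, therefore mark no direction for this position. Open, as far as these compounds go, is whether a primary amine, a carboxylic acid or a longer alkyl chain on this carbon would give a step beyond the scatter in this assay at all.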